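Chloro to fluoro exchange from compound 2: working notes

The compounds below may be only part of what the source reports. "The series", "measured", "known", "first", "only" and "open" are said of these compounds alone.

Measured so far:
compound 1, `COc1cc(O)c(C(=O)/C=C/c2ccc(F)cc2)c(OC)c1`, gives 37% in a functional assay on PC-3 cells (Homo sapiens), read by fluorescence and BrdU incorporation, with a stated time of 48 h, tested at 10 uM; on this read-out lower numbers stand for a stronger effect and higher numbers for a weaker effect at the one concentration tested
compound 2, `COc1cc(OC)c(C(=O)/C=C/c2ccc(Cl)cc2)c(OC)c1`, gives 15% in this assay

Compound 2 stands lowest of the two numbers in this assay; the nearest is compound 1, whose number lies higher by a margin beyond the usual scatter. Within the data shown here, compound 1 and compound 2 differ in more than one place, so their two values are noted as they stand and no single step is read from them.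

Compound 3, `COc1cc(OC)c(C(=O)/C=C/c2ccc(F)cc2)c(OC)c1`, differs from compound 2 in one place:
fluoro in place of chloro on an aromatic carbon

Among the measured compounds shown here, no pair of measured compounds shows this exchange, so its effect in this assay is not known from the series. The expectation for the step from compound 2 to compound 3 is a small change, a number 7 percentage points higher from compound 2 to compound 3 (within the scatter), toward a weaker effect, probably within the scatter. Compound 3 is estimated at 22%, with a range from 10% to 40%.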

Compound 3, a percentage reported as activity, at one concentration (the size of the read-out at that concentration, not a potency): 27%
Compound 3: the middle estimate sits 5 percentage points below what was measured; low and high end bracket the measured number.
By their numbers in this assay, from the lowest: compound 2; then compounds 3 and 1 (each within the scatter of the next).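

In this assay the exchange of 4-chlorophenyl to 4-fluorophenyl can now be read as a single change: it gives a number 12 percentage points higher from compound 2 to compound 3 (beyond the scatter) and shows that this place on the ring responds to the choice of halogen, with compound 2 the stronger of the pair. The second single change, methyl in place of hydrogen on an oxygen on an aromatic ring, gives a number 10 percentage points lower from compound 1 to compound 3 (within the scatter) and so cannot be told apart from the scatter. Nothing available bears on the reason for either step.

From the compounds shown here alone, whether this place also responds to bromo, methoxy or an amine remains open, as does whether the chloro-to-fluoro step holds on the core of compound 1, with its free hydroxyl. A single concentration also shows only a stronger or weaker effect at that concentration, for these compounds and for any later analogue.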